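The compounds below may be only part of what the source reports. "The series", "measured", "known", "first", "only" and "open" are said of these compounds alone.

In a functional assay on A-375 cells (Homo sapiens) for antiproliferative activity, read by MTT assay, with a stated time of 24 h, tested at 0.05 ug/mL (on this read-out lower numbers stand for a weaker effect and higher numbers for a stronger effect at the one concentration tested), compound 1 `COc1ccc2nc(C(=O)Nc3ccc(-c4ccccc4)cc3)c(C)c(O)c2c1` gives 1.98%, the highest of the three numbers measured, though each gap to it lies within the scatter. Compound 2 `Cc1c(C(=O)Nc2ccc(-c3ccccc3)cc2)nc2ccccc2c1O` gives 1.05%, and compound 3 `CCc1ccc2nc(C(=O)Nc3c(F)cc(-c4cccc(F)c4)cc3F)c(C)c(C(=O)O)c2c1` gives 0.95%. Going by the values given here, the only single step known, a number 0.9 percentage points lower from compound 1 to compound 2 (within the scatter), changed nothing beyond the scatter. Compound 4 `COc1ccc2nc(C(=O)Nc3ccc(-c4ccccc4)cc3)c(C)c(C(=O)O)c2c1` differs from compound 1 by carboxy in place of hydroxy on an aromatic carbon. Among the compounds with values here, compound 3 also carries a carboxy where compound 1 carries a hydroxy, and its number is as low as the others, but it differs in further places too, so no step is known for that pair. Nothing measured points to movement beyond the scatter. Compound 4 is therefore expected to give 1.5%, within 0% to 6%. The expected step is a number 0.5 percentage points lower from compound 1 to compound 4 (within the scatter).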

Compound 4, a percentage reported as inhibition, at one concentration (the size of the read-out at that concentration, not a potency): 1.26%
Compound 4: the middle estimate sits 0.2 percentage points above what was measured; low and high end bracket the measured number.
By their numbers in this assay, from the lowest: compounds 3, 2, 4 and 1 (each within the scatter of the next).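

At the position opposite the ring nitrogen, carboxy in place of hydroxy gives, in this assay, a number 0.7 percentage points lower from compound 1 to compound 4 (within the scatter). Going by these compounds alone, this is the first direct reading of this swap, which compound 3, differing in further places, could not give: on the core of compound 1, the two groups cannot be told apart here. No measurement at hand offers an explanation for this result. From the compounds shown here alone, whether an amine or a longer chain at this position would move the number beyond the scatter stays open. Also open, going by these compounds, is whether hydroxy and carboxy would still match at other concentrations.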